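The compounds below may be only part of what the source reports. "The series", "measured", "known", "first", "only" and "open" are said of these compounds alone.

Three compounds share one core. In an assay for inhibition of kynurenine 3-monooxygenase (Homo sapiens), read by mass spectrometry, with a stated time of 1 h (a lower number here means a stronger inhibitor, a higher number a weaker inhibitor), compound 1 `Cc1ccc([C@@H](C)Oc2cc3onc(CCC(=O)O)c3cc2Cl)nc1` gives 3.16 nM; compound 2 `C[C@@H](Oc1cc2oc(=O)n(CCC(=O)O)c2cc1Cl)c1ccc(F)cn1` gives 2.51 nM in this assay; and compound 3 `CCc1cc2oc(=O)n(CCC(=O)O)c2cc1Cl` gives 10 nM. Compound 3 therefore stands with the highest number of the three, the weakest inhibitor shown, and its gaps to compound 1 and to compound 2 both lie beyond the scatter. Compound 4 `O=C(O)CCn1c(=O)oc2cc(OCC3CC3)c(Cl)cc21` differs from compound 3 by cyclopropylmethoxy in place of ethyl on an aromatic carbon. Compound 1 and compound 2 also carry substituents joined through oxygen, and both give lower numbers than compound 3. A small downward step is therefore expected, a 2.0-fold lower number from compound 3 to compound 4 (0.30 log units; within the scatter). Compound 4 is expected to give about 5 nM, with a likely range from 1.6 nM to 16 nM.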

Compound 4, half-maximal inhibitory concentration: 10 nM
For compound 4 the middle estimate is 2.0-fold (0.30 log units) below the measured one; low and high end bracket the measured number.
By their numbers in this assay, from the lowest: compounds 2 and 1 (each within the scatter of the next); then compounds 3 and 4 (each within the scatter of the next).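

Replacing ethyl with cyclopropylmethoxy on this aromatic carbon, ortho to the chloro group, brings no change at the digits printed from compound 3 to compound 4 (within the scatter). Among these compounds, a larger group, with a three-membered ring and an added oxygen, is therefore tolerated here, which the earlier compounds could not show because no two of them differed in only one place. No measurement shown offers a reason for this flat result. On these data alone, whether an amine or a longer carbon chain at this carbon would move the number remains open. So does what sets compound 1 and compound 2 apart from compound 4.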